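A Thiophene Ester in Place of a Methoxyphenyl Ester

The compounds below may be only part of what the source reports. "The series", "measured", "known", "first", "only" and "open" are said of these compounds alone.

The study reads cytotoxicity in an ADME assay on Vero cells (Chlorocebus sabaeus) for cytotoxicity, read by MTT assay, with a stated time of 48 h; on this read-out lower numbers stand for stronger inhibition and higher numbers for weaker inhibition. Going by the values given here, compound 1, `CS(=O)(=O)NC1CCC(CN2CCN(c3cc(=O)c4cc(C(F)(F)F)cc([N+](=O)[O-])c4s3)CC2)CC1`, is the only member with a plain number: in this assay compound 1 gives 48.5 ug/mL. Compound 2, `COc1ccccc1C(=O)OC1CCC(CN2CCN(c3cc(=O)c4cc(C(F)(F)F)cc([N+](=O)[O-])c4s3)CC2)CC1`, reaches only a limit of the assay: in this assay compound 2 gives > 64 ug/mL. Among the compounds with values here, the one measured step, an at least 1.3-fold higher number from compound 1 to compound 2 (0.12 log units; that floor lies within the scatter), thus tells little beyond its direction, and its floor comes from the limit of > 64 ug/mL in this assay, at which 1 of the 2 values shown sits. Within the data shown here, compound 3, `O=C(OC1CCC(CN2CCN(c3cc(=O)c4cc(C(F)(F)F)cc([N+](=O)[O-])c4s3)CC2)CC1)c1cccs1`, differs from compound 2 by thiophen-2-yl in place of 2-methoxyphenyl on a carbonyl carbon, a change confined to the ester part, for which no measured step exists. The measured step rests on a different change and is not carried over. Compound 3 is therefore expected to stay near the level of the limit, with an estimated value of 60 ug/mL in a range from 30 ug/mL to 120 ug/mL. The expected step of an at least 1.0-fold lower number from compound 2 to compound 3 (0.02 log units; that floor lies within the scatter) is estimated to lie within the scatter.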

Compound 3, half-maximal inhibitory concentration: > 64 ug/mL
Compound 3 gave a limit, no number; the forecaster's own chance of this, stated with the estimate: 55%; at least 1.0-fold (0.02 log units) between middle value and limit.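

In this assay compound 3 gives > 64 ug/mL, which is a limit of the assay and not a number. Thiophen-2-yl on the carbonyl carbon therefore ends at the same limit as 2-methoxyphenyl, so a second ester joins the first there, and the step between these two esters cannot be read. Set against methanesulfonamido on the saturated ring carbon, ((thiophen-2-yl)carbonyl)oxy gives an at least 1.3-fold higher number from compound 1 to compound 3 (0.12 log units; that floor lies within the scatter), and this floor is fixed by the limit rather than by a measured value: the limit of > 64 ug/mL in this assay, at which 2 of the 3 values shown sit.

On these data alone, how far compound 2 and compound 3 actually lie beyond the limit remains open, as does any order between them. Also open, as far as these compounds go, is whether a plain number would return with a simple methyl group or an aminomethyl group on the carbonyl carbon, or with a free carboxylic acid in place of the ester.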